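Ring size on the chain and the minimum effective dose

The source may hold more compounds than are shown below. What is called first, only, known or untested is meant among the compounds shown, and "the series" means these compounds.

Measured so far:
Compound 1, `c1ccc2c(c1)CCC2CCCN1CCN(c2cccc3c2OCCO3)CC1`, gives 0.16 mg/kg in a functional assay on the whole organism for antagonist activity, with Rattus norvegicus as the target; a higher number here means that more compound is needed for the effect, a lower number that less compound is needed.
Compound 2, `c1ccc2c(c1)CC2CCCN1CCN(c2cccc3c2OCCO3)CC1`, gives 0.16 mg/kg in this assay.

Compound 2 stands level with compound 1 in this assay; the step of no change at the digits printed from compound 1 to compound 2 (within the scatter) shows that trading the nine-carbon bicyclic group for the eight-carbon one, on the saturated chain carbon three bonds from the ring amine nitrogen, left the minimum effective dose where it was.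

Compound 3, `c1ccc2c(c1)CC(CCCN1CCN(c3cccc4c3OCCO4)CC1)C2`, is not yet measured. It differs from compound 2 in this way: a group of 9 heavy atoms (9 carbon; one five-membered non-aromatic ring of carbon only, one six-membered aromatic ring of carbon only) in place of a group of 8 heavy atoms (8 carbon; one four-membered non-aromatic ring of carbon only, one six-membered aromatic ring of carbon only), on a saturated chain carbon, three bonds along the chain from an amine nitrogen in a ring

Within the data shown here, only the step from compound 1 to compound 2 bears on this change, and it is flat within the scatter. Among the measured compounds shown here, compound 3 carries the five-membered ring attached at a different carbon of that ring than compound 1 does, so the one measured step is a guide to ring size rather than to the point of attachment. With that caveat, the step of no change at the digits printed from compound 2 to compound 3 (within the scatter) is expected to lie within the scatter, in no clear direction.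

Compound 3 is therefore estimated at 0.16 mg/kg in this assay, with a range from 0.06 mg/kg to 0.45 mg/kg.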

Compound 3, minimum effective dose: 0.63 mg/kg
Compound 3: the middle estimate sits 3.9-fold (0.60 log units) below what was measured; the whole stated range lies below it.
By their numbers in this assay, from the lowest: compounds 1 and 2 (each within the scatter of the next); then compound 3.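

The attachment point of the group counts at this position, which the earlier pair could not show. Moving from 2,3-dihydro-1H-inden-1-yl to 2,3-dihydro-1H-inden-2-yl on the saturated chain carbon, three bonds along the chain from an amine nitrogen in a ring, keeps the atom count of the group the same, yet this assay records a 3.9-fold higher number from compound 1 to compound 3 (0.60 log units; beyond the scatter) for that change. The flat step between compounds 1 and 2 therefore does not mean that this position accepts any group of this kind, since the step of a 3.9-fold higher number from compound 2 to compound 3 (0.60 log units; beyond the scatter) shows a larger ring bringing a higher dose requirement here, while compound 1, with the same ring size, stands level with compound 2. No measurement in hand accounts for this difference.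

Going by these compounds, it remains open whether the gap tied to the attachment point would persist with a longer chain between the ring amine nitrogen and the group. Nor do these three compounds tell how a plain phenyl group on the same chain carbon would compare with either 2,3-dihydro-1H-inden-yl isomer.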